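The source may hold more compounds than are shown below. What is called first, only, known or untested is meant among the compounds shown, and "the series" means these compounds.

Measured compounds:
- compound 1, `CN1CCN(c2ccc(Nc3ncc4nc(Nc5ccc(F)cc5)n([C@H]5CCCN(S(=O)(=O)C6CC6)C5)c4n3)cc2)CC1`: 8.6 nM
- compound 2, `CN1CCN(c2ccc(Nc3ncc4nc(Nc5ccc(F)cc5)n([C@H]5CCN(C(=O)OC(C)(C)C)C5)c4n3)cc2)CC1`: 580 nM

In a functional assay on HCC827 cells (Homo sapiens) for antiproliferative activity, read by MTT assay, with a stated time of 72 h (on this read-out higher numbers stand for weaker inhibition and lower numbers for stronger inhibition), compound 2 gives 580 nM, the highest of the two numbers recorded. Compound 1 gives 8.6 nM, and the step from compound 1 to compound 2 is a 67-fold higher number from compound 1 to compound 2 (1.83 log units; beyond the scatter), a change of the whole group on the aromatic nitrogen. Compound 3, `CNC(=O)CN1CC[C@H](n2c(Nc3ccc(F)cc3)nc3cnc(Nc4ccc(N5CCN(C)CC5)cc4)nc32)C1`, keeps the pyrrolidinyl ring of compound 2 and alters only the substituent on its amine nitrogen: (methylcarbamoyl)methyl in place of tert-butoxycarbonyl on an amine nitrogen in a ring. Going by the values given here, no measured step alters this group alone; the step from compound 1 to compound 2 shows only that this part of the molecule can move the number a great deal. Compound 3 is therefore expected to fall below compound 2, yet with wide uncertainty, and its estimate in this assay is 120 nM, between 20 nM and 700 nM, corresponding to an expected step of a 4.8-fold lower number from compound 2 to compound 3 (0.68 log units; beyond the scatter).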

Compound 3, half-maximal inhibitory concentration: 1520 nM
The estimate for compound 3 lay 13-fold (1.10 log units) below the measured number, and the stated range ends below it.
By their numbers in this assay, from the lowest: compound 1; then compound 2; then compound 3.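

In this assay, the change from tert-butoxycarbonyl to (methylcarbamoyl)methyl on the amine nitrogen gives a 2.6-fold higher number from compound 2 to compound 3 (0.42 log units; beyond the scatter), which shows that this substituent moves the number on its own while the pyrrolidinyl ring stays in place, and that this exchange does not lower it. Set against the 1-(cyclopropylsulfonyl)piperidin-3-yl group, the 1-((methylcarbamoyl)methyl)pyrrolidin-3-yl group gives a 180-fold higher number from compound 1 to compound 3 (2.25 log units; beyond the scatter), so both pyrrolidinyl compounds shown lie far above compound 1. Nothing available here bears on the reason for either step.

Ring and substituent change together in every step from compound 1, which leaves open how much of that gap belongs to each. Also open, from the compounds shown here alone, is how a cyclopropylsulfonyl group on the pyrrolidinyl ring would read, or a carboxylic acid or a longer chain ending in an amine on that nitrogen.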